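Removing a Methoxy Group Beside the Phenol of Compound 3

A few compounds are considered here, and "the series" means these few. Any claim that something is new, unique, unknown or untested is made for them only; others in the source may bear on it.

The measured compounds and their numbers:
Compound 1, `COc1cc(/C=N/c2c(C#N)ncn2-c2ccc(F)cc2)cc(OC)c1OC`: in a functional assay on A549 cells (Homo sapiens) for antiproliferative activity, read by MTT assay, with a stated time of 48 h (a higher number here means a weaker inhibitor, a lower number a stronger inhibitor), compound 1 gives 9880 nM.
Compound 2, `N#Cc1ncn(-c2ccc(F)cc2)c1/N=C/c1ccc([N+](=O)[O-])cc1`: in this assay compound 2 gives 18100 nM.
Compound 3, `COc1cc(/C=N/c2c(C#N)ncn2-c2ccc(F)cc2)ccc1O`: in this assay compound 3 gives 13600 nM.

Compound 3 sits between the other two on the numbers shown. Its nearest neighbour is compound 2, and the gap between them lies within the usual scatter of this measurement; the gap to compound 1, the furthest of the three, also lies within that scatter. On these data, then, the three compounds cannot be told apart in this assay.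

Compound 4, `N#Cc1ncn(-c2ccc(F)cc2)c1/N=C/c1ccc(O)cc1`, has not yet been measured in this assay. It differs from compound 3 in one place: hydrogen in place of methoxy on an aromatic carbon. Within the data shown here, no pair of measured compounds shows this same change, so there is no measured step to lean on. Since the three measured compounds, which differ from one another in more than one place, all fall within the scatter of each other in this assay, a single change of this kind is expected to produce a step no larger than that scatter, with no clear direction.

The expected step of a 1.0-fold higher number from compound 3 to compound 4 (0.01 log units; within the scatter) is estimated to be none beyond the scatter. Compound 4 is therefore expected to give about 14000 nM, within a range from 6000 nM to 35000 nM.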

Compound 4, half-maximal inhibitory concentration: 16300 nM
For compound 4 the middle estimate is 1.2-fold (0.07 log units) below the measured one; measured number inside the range.
By their numbers in this assay, from the lowest: compounds 1, 3, 4 and 2 (each within the scatter of the next).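

In this assay, among these compounds, the exchange of methoxy for hydrogen, on an aromatic carbon ortho to a hydroxy group, gives a 1.2-fold higher number from compound 3 to compound 4 (0.08 log units; within the scatter) and is the first single-place comparison at this position, so for this pair the methoxy group can go without a step that stands out from the scatter. Compound 4 also supplies a second single-place comparison, hydroxy in place of nitro on an aromatic carbon, which gives a 1.1-fold lower number from compound 2 to compound 4 (0.05 log units; within the scatter) and likewise stays within the scatter, so neither change separates the compounds in this assay. No measurement is available that bears on what lies behind either step.

The compounds shown leave open whether any group on this aromatic carbon can produce a step beyond the scatter, for example an amine, a carboxylic acid or a longer chain such as ethoxy in place of methoxy. They also leave open what the hydroxy group itself contributes, as no pair shown exchanges it for hydrogen alone.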